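Acid Ceramidase Inhibitors: From Compound 3 Toward Compound 4

A few compounds are considered here, and "the series" means these few. Any claim that something is new, unique, unknown or untested is made for them only; others in the source may bear on it.

Measured compounds:
compound 1 `CN1CCC(c2ccc3c(c2)oc(=O)n3C(=O)NCCOCc2ccccc2)CC1`, 215 nM
compound 2 `CC(C)CNC(=O)n1c(=O)oc2cc(C3CCCN(C)C3)ccc21`, 1750 nM
compound 3 `CC(C)CN1CCN(c2ccc3c(c2)oc(=O)n3C(=O)NCCCCc2ccccc2)CC1`, 127 nM

Three compounds share a core and were tested in an assay on HEK293 cells for inhibition of acid ceramidase (Homo sapiens), read by fluorescence, with stated times of 10 min and 3 h; a lower number here means a stronger inhibitor, a higher number a weaker inhibitor. Compound 3 gives 127 nM, the lowest of the three numbers. Compound 1, at 215 nM, lies within the usual scatter of compound 3, so the two cannot be told apart on these data. Compound 2, at 1750 nM, sits far beyond the scatter, the weakest of the set.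

Compound 4 `CN1CCN(c2ccc3c(c2)oc(=O)n3C(=O)NCCCCc2ccccc2)C(=O)C1` has not yet been measured. It differs from compound 3 in one place: 4-methyl-2-oxopiperazin-1-yl in place of 4-isobutylpiperazin-1-yl on an aromatic carbon. Among the measured compounds shown here, no measured pair in this set makes that same change, so its effect has to be guessed from the structures alone.

The shared ring system and the longer amide chain of compound 3 are kept in compound 4. The group that enters is somewhat smaller than the one that leaves and carries a carbonyl within the ring. A moderate loss of inhibition is expected, a step somewhat beyond the scatter, though a result within the scatter would not be surprising. In this assay compound 4 is estimated at 350 nM, with a likely range from 120 nM to 1100 nM. The step from compound 3 to compound 4 is therefore expected to be a 2.8-fold higher number from compound 3 to compound 4 (0.44 log units; beyond the scatter).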

Compound 4, half-maximal inhibitory concentration: 52 nM
The estimate for compound 4 lay 6.7-fold (0.83 log units) above the measured number; the measured number lies below the stated range.
By their numbers in this assay, from the lowest: compound 4; then compounds 3 and 1 (each within the scatter of the next); then compound 2.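

In this assay, among the compounds shown here, putting 4-methyl-2-oxopiperazin-1-yl in place of 4-isobutylpiperazin-1-yl on the aromatic carbon gives a 2.4-fold lower number from compound 3 to compound 4 (0.39 log units; beyond the scatter), the only step in this set between compounds that differ in one place. For the compounds shown here, this shows that the position accepts a six-membered ring carrying a carbonyl, with fewer heavy atoms than the ring it replaces, and that the number falls rather than rises, which the earlier compounds, with their differences in more than one place, could not show. No measurement shown here accounts for the lower number, so the reason for the step remains unknown.

The swap alters two features at once, the group on the ring nitrogen and the carbonyl in the ring, so 4-methylpiperazin-1-yl and 4-isobutyl-2-oxopiperazin-1-yl would each be needed to tell which feature goes with the step. Going by these compounds alone, also open is whether the 4-methyl-2-oxopiperazin-1-yl group gives a similar step when the chain on the amide is the one in compound 1 rather than the one shared by compound 3 and compound 4.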